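Tetradecylamide serine imines: aryl substituent swaps and cytotoxicity

A few compounds are considered here, and "the series" means these few. Any claim that something is new, unique, unknown or untested is made for them only; others in the source may bear on it.

Measured compounds:
- compound 1 `CCCCCCCCCCCCCCNC(=O)[C@H](CO)/N=C/c1cccc(OC)c1`: 31300 nM
- compound 2 `CCCCCCCCCCCCCCNC(=O)[C@H](CO)/N=C/c1ccc(OC)cc1`: 28100 nM
- compound 3 `CCCCCCCCCCCCCCNC(=O)[C@H](CO)/N=C/c1ccccc1[N+](=O)[O-]`: 21700 nM

The three share one core and differ only in the aryl group on the carbon with a double bond to nitrogen. In a functional assay on cells (Homo sapiens) for cytotoxicity, read by MTT assay, with a stated time of 24 h (a higher number here means a weaker inhibitor, a lower number a stronger inhibitor), compound 1 gives 31300 nM, compound 2 gives 28100 nM and compound 3 gives 21700 nM. Compound 2 stands second highest of the three numbers; its nearest neighbour is compound 1, with a 1.1-fold lower number from compound 1 to compound 2 (0.05 log units; within the scatter), and its furthest is compound 3, with a 1.3-fold lower number from compound 2 to compound 3 (0.11 log units; within the scatter). The remaining pair shows a 1.4-fold lower number from compound 1 to compound 3 (0.16 log units; within the scatter). Going by the values given here, no pair of compounds is separated by more than the scatter, so no ordering among them can be claimed.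

Compound 4 `CCCCCCCCCCCCCCNC(=O)[C@H](CO)/N=C/c1ccccc1OC` has not yet been measured. The change from compound 2 is 2-methoxyphenyl in place of 4-methoxyphenyl on a carbon with a double bond to nitrogen. All three measured steps are swaps of the aryl substituent at the same place, and each stayed within the scatter, so no step beyond the scatter is expected in this assay for compound 4 either. Compound 4 is expected to give about 27000 nM, with a range of 14000 nM to 54000 nM. The expected step is a 1.0-fold lower number from compound 2 to compound 4 (0.02 log units; within the scatter).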

Compound 4, half-maximal inhibitory concentration: 12500 nM
The estimate for compound 4 lay 2.2-fold (0.33 log units) above the measured number, outside the stated range (below it).
By their numbers in this assay, from the lowest: compounds 4, 3, 2 and 1 (each within the scatter of the next, the first and the last beyond it).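

In this assay, going by these compounds alone, 2-methoxyphenyl in place of 4-methoxyphenyl gives a 2.2-fold lower number from compound 2 to compound 4 (0.35 log units; beyond the scatter) and 2-methoxyphenyl in place of 3-methoxyphenyl gives a 2.5-fold lower number from compound 1 to compound 4 (0.40 log units; beyond the scatter) as the first aryl swaps at this carbon with a double bond to nitrogen to pass the scatter, both modest, and the groups exchanged hold the same atoms, joined differently. Methoxy in place of nitro on an aromatic carbon gives a 1.7-fold lower number from compound 3 to compound 4 (0.24 log units; within the scatter) and stays within the scatter, so compound 3 and compound 4 cannot be ordered and the 2-substituted aryl compounds cannot be separated from each other. Nothing at hand accounts for the step. On these data alone, whether a 2-ethoxyphenyl or 2-aminophenyl group at the same carbon would follow compound 4 remains open. Also open, as far as these compounds go, is whether the step would hold with a shorter chain in place of the tetradecyl chain.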